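This account rests on a few compounds, and the source may have more. Where it says the series, first, only, none or still open, it means among the compounds named here.

Measured compounds:
- Compound 2, `CCCCCCCCCCc1cn(C[C@H](O)[C@H]2OC(=O)C(OCc3ccccc3)=C2OCc2ccccc2)nn1`: in a functional assay on A549 cells (Homo sapiens) for antiproliferative activity, read by MTT assay, with a stated time of 72 h (a lower number here means a stronger inhibitor, a higher number a weaker inhibitor), compound 2 gives 6750 nM.
- Compound 1, `O=C1O/C(=C\Cn2cc(-c3cc(C(F)(F)F)cc(C(F)(F)F)c3)nn2)C(OCc2ccccc2)=C1OCc1ccccc1`: in this assay compound 1 reaches only a limit, > 100000 nM.

Among the compounds with values here, compound 2 stands alone as the only real number in this assay; the other entry is the limit of > 100000 nM in this assay, at which 1 of the 2 values shown sits, so there is no measured step against which its value can be set.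

Compound 3, `Cc1ccc(S(=O)(=O)NCc2cn(C[C@H](O)[C@H]3OC(=O)C(OCc4ccccc4)=C3OCc3ccccc3)nn2)cc1`, is the unmeasured member. It differs from compound 2 in one place: ((4-methylphenyl)sulfonyl)amino in place of nonyl on a saturated chain carbon bound to an aromatic carbon. Within the data shown here, no measured pair shows this kind of exchange, so the direction and size of the step rest on expectation alone.

The step from compound 2 to compound 3 is expected to run towards weaker inhibition and to exceed the usual scatter, a 4.4-fold higher number from compound 2 to compound 3 (0.65 log units; beyond the scatter). Compound 3 is therefore estimated at 30000 nM in this assay, with a plausible range from 8000 nM to 110000 nM, and a real chance that only a limit is recorded.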

Compound 3, half-maximal inhibitory concentration: 16800 nM
Beside the measured number, compound 3's estimate is 1.8-fold (0.25 log units) above it, within the range that was stated.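

In this assay the position on a saturated chain carbon bound to an aromatic carbon now has its first measured change, with a 2.5-fold higher number from compound 2 to compound 3 (0.40 log units; beyond the scatter) when ((4-methylphenyl)sulfonyl)amino takes the place of nonyl. The exchange therefore carries a modest loss and does not abolish activity: compound 3 still gives a real number of 16800 nM even though the entering group brings an aromatic ring, a hydrogen-bond donor and hydrogen-bond acceptors that nonyl does not have. For these two compounds, then, a measurable antiproliferative value does not rest on a plain alkyl chain at this place, but nothing measured here gives a reason for the step.

As far as these compounds go, whether the length of the chain sets the value of compound 2 stays open, as does what a shorter chain, a longer chain or an amine would give at this place. It is also open which part of the ((4-methylphenyl)sulfonyl)amino group accounts for the step, the sulfonyl, the amino hydrogen or the 4-methylphenyl ring.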